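Ethynyl for methoxy on a urea-bearing phenyl

The compounds below may be only part of what the source reports. "The series", "measured", "known", "first", "only" and "open" are said of these compounds alone.

Of the compounds shown here, three built on one shared core have been tested in a functional assay on MDA-MB-231 cells (Homo sapiens) for antiproliferative activity, read by MTT assay, with a stated time of 72 h; a higher number here means a weaker inhibitor, a lower number a stronger inhibitor. Compound 1 `O=C(Nc1ccc(-c2noc(-c3cccc(NS(=O)(=O)c4cccc(Cl)c4)c3)n2)c(Cl)c1)c1cccnc1` returns only the limit of this assay, > 10000 nM. Compound 2 `O=C(Nc1ccccc1)Nc1cccc(-c2nc(-c3ccc(NC(=O)c4cccnc4)cc3Cl)no2)c1` likewise returns only the limit, > 10000 nM. Within the data shown here, compound 3 `COc1cccc(NC(=O)Nc2cccc(-c3nc(-c4ccc(NC(=O)c5cccnc5)cc4Cl)no3)c2)c1` gives 6700 nM, the single definite number among the three, and so it alone offers a footing (the limit of > 10000 nM in this assay, at which 2 of the 3 values shown sit). The exchange of (3-chlorophenyl)sulfonyl for phenylcarbamoyl on a nitrogen on an aromatic ring reads a step that the two limits leave unreadable from compound 1 to compound 2. Two measured steps lead to the definite number: an at least 1.4-fold lower number from compound 1 to compound 3 (0.17 log units; that floor lies within the scatter) and an at least 1.4-fold lower number from compound 2 to compound 3 (0.17 log units; that floor lies within the scatter), the latter being methoxy in place of hydrogen on an aromatic carbon, with a floor that lies within the scatter.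

Compound 4 `C#Cc1cccc(NC(=O)Nc2cccc(-c3nc(-c4ccc(NC(=O)c5cccnc5)cc4Cl)no3)c2)c1` differs from compound 3 by ethynyl in place of methoxy on an aromatic carbon. Among the measured compounds shown here, no measured step swaps methoxy for another small group, and the sole step that installs methoxy, an at least 1.4-fold lower number from compound 2 to compound 3 (0.17 log units; that floor lies within the scatter), is readable only as a floor inside the scatter. Nothing shown supports a sizeable move in either direction. The step expected for compound 4 is a 1.0-fold higher number from compound 3 to compound 4 (0.02 log units; within the scatter), no larger than the scatter. The estimate for compound 4 is 7000 nM, spanning 2500 nM to 20000 nM, with a real chance that only the limit is reported.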

Compound 4, half-maximal inhibitory concentration: > 10000 nM
Compound 4: only a limit was reported; the forecaster's own chance of this, stated with the estimate: 35%; middle value at least 1.4-fold (0.15 log units) from the limit.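

In this assay compound 4 gives > 10000 nM, which is a limit of the assay and not a number. The exchange of methoxy for ethynyl at this position therefore reads only as an at least 1.4-fold higher number from compound 3 to compound 4 (0.17 log units; that floor lies within the scatter), so it shows no change beyond the scatter, but it does show that ethynyl, unlike methoxy, gives no definite number here. Ethynyl thus joins hydrogen at this position in reaching only the limit, compound 3 stays the single compound with a definite number, and the steps that end at compound 4 from compound 1 and compound 2 cannot be read, as limits stand at both ends: the limit of > 10000 nM in this assay, at which 3 of the 4 values shown sit.

The compounds shown leave open whether another small group on this ring, such as an amine, fluoro or ethoxy, would give a definite number, or whether methoxy is a special case at all, since its one step is an at least 1.4-fold lower number from compound 2 to compound 3 (0.17 log units; that floor lies within the scatter). They also leave open whether methoxy or ethynyl elsewhere on this ring would read differently from the position tested here.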